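Exchanging a fluoropyrazole for an isopropoxy group: stability outlook

The source may report more compounds than this note shows. Statements on the series, on what has been measured and on what is new or still open speak of the compounds shown alone.

Three compounds have been measured in an ADME assay on microsomes from liver (Mus musculus) for metabolic stability, read by HPLC, using NADPH, with a stated time of 60 min, tested at 1 uM, in the presence of a further agent that is not named here; a lower number here means that the compound disappears faster, a higher number that the compound lasts longer:

Compound 1 `Cc1cc(-n2nccn2)cc(C(=O)NNS(=O)(=O)c2ccccc2)c1F` gives 0.0333 h.
Compound 2 `Cc1cc(-c2ncccn2)cc(C(=O)NNS(=O)(=O)c2ccccc2)c1F` gives 0.1 h.
Compound 3 `Cc1cc(C(=O)NNS(=O)(=O)c2ccccc2F)cc(-n2cc(F)cn2)c1` gives 0.0667 h.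

Compound 3 stands second highest of these three numbers. Its nearest neighbour is compound 2, whose value lies within the usual scatter of compound 3, and the furthest is compound 1, also within the scatter, so no order among the three can be claimed.

Among the compounds with values here, the one step that has been measured between compounds differing in a single place is a 3.0-fold higher number from compound 1 to compound 2 (0.48 log units; beyond the scatter), a swap of one nitrogen-containing ring for another. It does not bear on the change now at hand, which is isopropoxy in place of 4-fluoro-1H-pyrazol-1-yl on an aromatic carbon, giving compound 4 `Cc1cc(OC(C)C)cc(C(=O)NNS(=O)(=O)c2ccccc2F)c1`. Nothing in the measured set tells how a move from an aromatic ring to an open alkoxy group at this position affects this assay.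

Within the data shown here, with no guiding step, the expected change is none beyond the scatter: a 1.1-fold lower number from compound 3 to compound 4 (0.05 log units; within the scatter). Compound 4 is therefore estimated at 0.06 h, with a range from 0.02 h to 0.15 h.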

Compound 4, half-life: < 0.0334 h
Compound 4 gave a limit, no number; the forecaster's own chance of this, stated with the estimate: 5%; middle value at least 1.7-fold (0.25 log units) away from the limit.
By their numbers in this assay, from the lowest: compounds 1, 3 and 2 (each within the scatter of the next, the first and the last beyond it).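

In this assay compound 4 gives < 0.0334 h, which is a limit of the assay and not a number. Isopropoxy in place of 4-fluoro-1H-pyrazol-1-yl gives an at least 1.9-fold lower number from compound 3 to compound 4 (0.30 log units; that floor lies within the scatter), so this first open group without a ring at this position brings no gain in half-life, though the true size of the step stays unknown and its floor alone cannot show a real drop. Compound 4 is the only compound shown that reaches this limit: the limit of < 0.0334 h in this assay, at which 1 of the 4 values shown sits.

The compounds shown leave open whether this result belongs to isopropoxy alone or extends to other groups without a ring at this position. From the compounds shown here alone, a methoxy group, an amine or a carboxylic acid in the same place could each read differently in this assay, and the actual half-life of compound 4 also remains unknown.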